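Fluorine Removed at the Far Ring: No Shift Expected

This account rests on a few compounds, and the source may have more. Where it says the series, first, only, none or still open, it means among the compounds named here.

Compound 1 `FC(F)(F)c1cccc(NC(=S)Nc2cccc(Br)c2)c1` gives 9200 nM in an ADME assay on MT4 cells (Homo sapiens) for cytotoxicity; a higher number here means that more compound is tolerated, a lower number that less compound is tolerated.
Compound 2 `CCOC(=O)c1ccc(NC(=S)Nc2cccc(C(F)(F)F)c2)cc1` gives 23000 nM in this assay.
Compound 3 `Fc1ccc(NC(=S)Nc2cccc(C(F)(F)F)c2)cc1` gives 31000 nM in this assay.

Compound 3 carries the largest number of the three, but it is not clearly apart from compound 2: the step of a 1.3-fold higher number from compound 2 to compound 3 (0.13 log units; within the scatter) lies within the scatter, so the two cannot be ordered. Only compound 1 is clearly set apart, through a 3.4-fold higher number from compound 1 to compound 3 (0.53 log units; beyond the scatter), a modest step that comes with the exchange of the whole ring on the amide-type nitrogen.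

Compound 4 `FC(F)(F)c1cccc(NC(=S)Nc2ccccc2)c1` differs from compound 3 by a single point: hydrogen in place of fluoro on an aromatic carbon.

Within the data shown here, of the measured steps, the one from compound 2 to compound 3 bears most directly on this change, since it alters the same aromatic carbon of the same ring, and it stayed within the scatter despite swapping a much larger group for fluoro. The step from compound 1 to compound 3 is larger but involves a different ring pattern and a bromo group, so it speaks less to the loss of one fluorine. In this assay the expected step of a 1.1-fold lower number from compound 3 to compound 4 (0.06 log units; within the scatter) is therefore small, with no direction beyond the scatter. Compound 4 is expected to give 27000 nM, in a range from 12000 nM to 60000 nM.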

Compound 4, half-maximal cytotoxic concentration: 39000 nM
The estimate for compound 4 lay 1.4-fold (0.16 log units) below the measured number, and the stated range covers the measured number.
By their numbers in this assay, from the lowest: compound 1; then compounds 2, 3 and 4 (each within the scatter of the next).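

In this assay the read-out does not separate hydrogen from fluoro on this aromatic carbon (the step is a 1.3-fold higher number from compound 3 to compound 4 (0.10 log units; within the scatter)), so losing the single fluorine from the 4-fluorophenyl ring leaves no change that can be read. The bare phenyl also cannot be separated from the ethoxycarbonyl compound (the step is a 1.7-fold higher number from compound 2 to compound 4 (0.23 log units; within the scatter)), which means that hydrogen, fluoro and ethoxycarbonyl on this carbon all lie within the scatter of one another, a wider set than the earlier pair alone could show. The one clear separation remains that of the bromo compound (the step is a 4.2-fold higher number from compound 1 to compound 4 (0.63 log units; beyond the scatter)), a modest step that comes with hydrogen in place of bromo, and so among these compounds only the one carrying bromo stands apart.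

Whether an amine or a carboxylic acid on this same aromatic carbon would stay within that band remains open, since every group shown there so far leaves the number where it is. The compounds shown offer no measured account of why the bromo compound stands apart or why the other three do not separate.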